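Swapping a methyl for thiophene at the alkynyl carbinol

The compounds below may be only part of what the source reports. "The series", "measured", "known", "first", "only" and "open" are said of these compounds alone.

Measured compounds:
compound 1 `CN(C)CCN(C)c1cc(-c2cn[nH]c2)c2cc(C#CC(C)(O)c3nccs3)ccc2n1`, 160 nM in an assay for inhibition of mitogen-activated protein kinase kinase kinase 14 (Homo sapiens), read by luminescence and ADP-Glo, with a stated time of 120 min, in the presence of a further agent that is not named here; a higher number here means a weaker inhibitor, a lower number a stronger inhibitor
compound 2 `CN1CCN(c2cc(-c3cn[nH]c3)c3cc(C#CC(C)(O)c4nccs4)ccc3n2)CC1`, 175 nM
compound 3 `CC(C)(O)C#Cc1ccc2nccc(-c3cn[nH]c3)c2c1`, 1720 nM

Compound 3 gives the highest number of the three in this assay, so it is the weakest of the measured set. Compound 4 `CC(O)(C#Cc1ccc2nccc(-c3cn[nH]c3)c2c1)c1cccs1` differs from it by thiophen-2-yl in place of methyl on a saturated chain carbon bound to an oxygen on a saturated carbon, a saturated chain carbon and a triple-bonded carbon. Among the measured compounds shown here, the only single-place step available, a 1.1-fold higher number from compound 1 to compound 2 (0.04 log units; within the scatter), changes a different part of the molecule and says nothing about this carbinol group. Compounds 1 and 2 carry a heteroaryl at that carbinol carbon and give far lower numbers than compound 3, but they also carry an amino substituent on the core, so the two changes cannot be separated. A moderate step is therefore expected for compound 4, in the direction of a lower number, estimated as a 2.5-fold lower number from compound 3 to compound 4 (0.39 log units; beyond the scatter). Compound 4 is expected at 700 nM, within 250 nM to 2500 nM.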

Compound 4, half-maximal inhibitory concentration: 524 nM
Compound 4: the middle estimate sits 1.3-fold (0.13 log units) above what was measured, and the stated range covers the measured number.
By their numbers in this assay, from the lowest: compounds 1 and 2 (each within the scatter of the next); then compound 4; then compound 3.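

Measured in this assay the swap of methyl for thiophen-2-yl on the carbinol carbon gives a real gain on its own (a 3.3-fold lower number from compound 3 to compound 4 (0.52 log units; beyond the scatter)), with no amino substituent on the core. This position therefore accepts an aromatic ring, which compound 1 and compound 2 could not show, as they differ from compound 3 in two places at once. Nothing available explains the gain. As far as these compounds go, whether a phenyl ring, a longer alkyl chain or an amine at this carbon would do better or worse stays open. So does how much the amino substituents on the core contribute to the lower numbers of compound 1 and compound 2.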